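This account rests on a few compounds, and the source may have more. Where it says the series, first, only, none or still open, it means among the compounds named here.

Compound 1 `Cn1cc(C2=C(c3n[nH]c4ncccc34)C(=O)NC2=O)c2ccccc21`: 62000 nM
Compound 2 `Cn1cc(C2=C(c3nn(CCn4ccnc4)c4ncccc34)C(=O)NC2=O)c2ccccc21`: > 100000 nM

In a functional assay on KB cells (Homo sapiens) for antiproliferative activity, read by MTT assay, with a stated time of 48 h (a higher number here means a weaker inhibitor, a lower number a stronger inhibitor), compound 1 gives 62000 nM. Compound 2 reaches only a limit in this assay, > 100000 nM, so no exact number stands for it. Going by the values given here, the single measured step, an at least 1.6-fold higher number from compound 1 to compound 2 (0.20 log units; that floor lies within the scatter), is therefore only a floor, set by the limit of > 100000 nM in this assay, at which 1 of the 2 values shown sits. Compound 3 `Cn1cc(C2=C(c3nn(CCn4ccnc4)c4ncccc34)C(=O)N(c3ccccc3)C2=O)c2ccccc21` differs from compound 2 by phenyl in place of hydrogen on an amide-type nitrogen in a ring. Among the compounds with values here, no measured pair alters the amide-type nitrogen in the ring, so nothing among the data speaks to this change directly, and the only comparison available, from compound 1 to compound 2, is itself bounded by the limit. Compound 2 already sits at the limit of this assay. The expectation for compound 3 is that it stays there or weakens further, an estimated step that the limit leaves unreadable from compound 2 to compound 3. Compound 3 is thus expected to give about 150000 nM, within 60000 nM to 400000 nM, most probably reported again only as a limit.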

Compound 3, half-maximal inhibitory concentration: > 100000 nM
Compound 3 gave a limit, no number (the forecaster's own chance of this, stated with the estimate: 75%); the middle value is on the limit's open side.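

In this assay compound 3 gives > 100000 nM, a limit and not a number. No step from compound 2 to compound 3 can be read, because both compounds stand only as limits: the limit of > 100000 nM in this assay, at which 2 of the 3 values shown sit.

The compounds shown leave open whether phenyl on the amide-type nitrogen in the ring changes activity at all, and how far compound 2 and compound 3 lie past that limit.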